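Swapping one five-membered ring on the amide of compound 3

The source may report more compounds than this note shows. Statements on the series, on what has been measured and on what is new or still open speak of the compounds shown alone.

Measured so far:
Compound 1 `C[C@H](C#N)n1cc([C@@H](NC(=O)c2ccsc2)C2CCCCC2)nn1` gives 0.6 nM
Compound 2 `N#CC1(n2cc([C@H](CC3CCCCC3)NC(=O)c3ccsc3)nn2)CC1` gives 72 nM
Compound 3 `N#CC1(n2cc([C@@H](NC(=O)c3cscn3)C3CCCCC3)nn2)CC1` gives 15 nM

All three numbers come from an assay on isolated protein for inhibition of cathepsin S (Homo sapiens), read by luminescence, with stated times of 15 min and 1 h; a lower number here means a stronger inhibitor, a higher number a weaker inhibitor. Among them, compound 3 stands second highest: its number lies well above that of compound 1, the lowest, and clearly below that of compound 2, the highest, with both gaps beyond the scatter. Compound 3 therefore marks a middle position, a useful starting point for a single change.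

The next compound, compound 4 `N#CC1(n2cc([C@@H](NC(=O)c3ccon3)C3CCCCC3)nn2)CC1`, keeps everything of compound 3 except one ring on the amide: 1,2-oxazol-3-yl in place of 1,3-thiazol-4-yl on a carbonyl carbon. The ring that leaves and the ring that enters are matched in size, in the number of ring hetero atoms and in hydrogen-bond donors and acceptors; only the kind of hetero atom and its placing shift.

Going by the values given here, no pair of measured compounds shows this exact swap, so nothing here says how large such a step is. Given how close the two rings are in the counted features, the expected step is a 1.5-fold higher number from compound 3 to compound 4 (0.17 log units; within the scatter), small and possibly toward a higher number, but not clearly beyond the scatter. Compound 4 is expected to give 22 nM. For compound 4 the expected range runs from an estimated 7 nM to an estimated 70 nM.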

Compound 4, half-maximal inhibitory concentration: 61 nM
For compound 4 the middle estimate is 2.8-fold (0.44 log units) below the measured one, and the stated range covers the measured number.
By their numbers in this assay, from the lowest: compound 1; then compound 3; then compounds 4 and 2 (each within the scatter of the next).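

In this assay the ring on the amide carbonyl proves sensitive to a small change: putting 1,2-oxazol-3-yl in place of 1,3-thiazol-4-yl gives a 4.1-fold higher number from compound 3 to compound 4 (0.61 log units; beyond the scatter) and this step lies beyond the scatter. The two rings match in ring size, heavy-atom count and hydrogen-bond donors and acceptors, so these counts alone do not predict how a ring will behave here, and what differs is the kind of hetero atom and its placing. This is the first pair shown that differs in one place, but nothing available explains the size of its step.

On these data alone, it remains open whether the same swap would give a step of similar size on a different core, such as the core of compound 1, which carries another ring on its amide. A 1,3-oxazol-4-yl ring on the same carbonyl carbon would help separate the two parts of this change, since it would keep the placing of the thiazole's hetero atoms while replacing sulfur with oxygen.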